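A few compounds are considered here, and "the series" means these few. Any claim that something is new, unique, unknown or untested is made for them only; others in the source may bear on it.

Within the data shown here, compound 2 `Cc1nc(S(C)(=O)=O)ccc1Oc1ncnc(OC2CCN(C(=O)OC3(C(F)(F)F)CCC3)CC2)c1F` stands at the top of the two numbers so far: in a functional assay on isolated protein for inhibition of Glucose-dependent insulinotropic receptor (Rattus norvegicus), read by HTRF and cAMP accumulation (a higher number here means a larger maximal response, a lower number a smaller maximal response), compound 2 gives 82%, while compound 1 `Cc1nc(S(C)(=O)=O)ccc1Oc1ncnc(OC2CCN(C(=O)OC(C)C)CC2)c1F` gives 77%, and the step of a number 5 percentage points higher from compound 1 to compound 2 (within the scatter) lies within the scatter. Compound 3 `Cc1nc(S(C)(=O)=O)ccc1Oc1ncnc(OC2CCN(C(=S)OC3(C)CC3)CC2)c1F` differs from compound 2 by a group of 7 heavy atoms (5 carbon, 1 oxygen, 1 sulfur; one three-membered non-aromatic ring of carbon only) in place of a group of 11 heavy atoms (6 carbon, 2 oxygen, 3 fluorine; one four-membered non-aromatic ring of carbon only), on an amine nitrogen in a ring. Among the measured compounds shown here, no measured step touches this part of the molecule in the same way; the one step known, at the same oxygen, changed little. Compound 3 is therefore expected to change by about a number 4 percentage points lower from compound 2 to compound 3 (within the scatter) in this assay, nothing beyond the scatter. The estimate for compound 3 is 78%, within 62% to 92%.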

Compound 3, largest response reached (reported as efficacy), in percent of the reference or control that the assay uses: 49%
Beside the measured number, compound 3's estimate is 29 percentage points above it, outside the stated range (below it).
By their numbers in this assay, from the lowest: compound 3; then compounds 1 and 2 (each within the scatter of the next).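

The group on the amine nitrogen in a ring is not as tolerant as the earlier step suggested. In this assay, the group with a sulfur and a three-membered ring gives a number 33 percentage points lower from compound 2 to compound 3 (beyond the scatter), and also a number 28 percentage points lower from compound 1 to compound 3 (beyond the scatter). Nothing available explains this drop.

The compounds shown leave open whether the sulfur or the three-membered ring accounts for the loss, as the two enter together. A carbonyl counterpart of compound 3, with oxygen in place of sulfur, or a tert-butyl group on the sulfur-bearing group, would begin to separate them.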